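Replacing a Small Methyl with a Methyl-Thiazole Ring

The compounds below may be only part of what the source reports. "The series", "measured", "known", "first", "only" and "open" are said of these compounds alone.

Measured compounds:
compound 1 `CN(C)c1ccc(C(=O)Nc2cccc(NC(=O)COc3ccc4c(c3)NC(=O)CC4)c2)cc1` gives 3140 nM in an assay on isolated protein for inhibition of Rho-associated protein kinase 2 (Homo sapiens), read by scintillation counting, radiometric assay and 33P incorporation, with a stated time of 40 min, in the presence of a further agent that is not named here; a higher number here means a weaker inhibitor, a lower number a stronger inhibitor
compound 2 `Cc1coc2cc(OCC(=O)Nc3cccc(NC(=O)c4ccc(N(C)C)cc4)c3)ccc2c1=O` gives 2150 nM in this assay
compound 3 `CC(=O)Nc1cccc(NC(=O)COc2ccc3c(=O)ccoc3c2)c1` gives 136 nM in this assay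

Among these three, compound 3 holds the lowest number, and both gaps to it lie beyond the usual scatter: compound 2 sits a good deal higher, and compound 1 higher still. Compounds 1 and 2 differ from compound 3 in more than one place, so no single step can be read from them; their values show only that the two larger amide-bearing members of this set are weaker inhibitors than compound 3.

Compound 4 `Cc1nc(C(=O)Nc2cccc(NC(=O)COc3ccc4c(=O)ccoc4c3)c2)cs1` is the next compound to be measured. It differs from compound 3 in one place: 2-methyl-1,3-thiazol-4-yl in place of methyl on a carbonyl carbon. The shared core and the ether-linked amide of compound 3 are kept unchanged.

Among the measured compounds shown here, no step between measured compounds matches this change, so the expectation rests on the standing of compound 3 alone. A step of modest size is expected, most likely towards a somewhat higher number, though a result within the scatter would not surprise. The expected step from compound 3 to compound 4 is a 2.1-fold higher number from compound 3 to compound 4 (0.31 log units; beyond the scatter). Compound 4 is therefore estimated at 280 nM, within a range from 80 nM to 1000 nM.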

Compound 4, half-maximal inhibitory concentration: 33 nM
The estimate for compound 4 lay 8.5-fold (0.93 log units) above the measured number, outside the stated range (below it).
By their numbers in this assay, from the lowest: compound 4; then compound 3; then compounds 2 and 1 (each within the scatter of the next).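

In this assay the change on this carbonyl carbon gives a 4.1-fold lower number from compound 3 to compound 4 (0.62 log units; beyond the scatter), so the single methyl can give way to the much larger 2-methyl-1,3-thiazol-4-yl and inhibition still gets stronger. Among the compounds shown here, this is the first direct reading at this position: compounds 1 and 2 also carry larger groups here and have higher numbers than compound 3, but they differ from it in more than one place, so their steps cannot be read and they gave no sign of how a larger group alone would behave. No measurement shown here accounts for the gain.

On these data alone, it remains open whether the gain needs this particular ring, with its sulfur, its nitrogen and its methyl, or whether another group on the same carbonyl carbon would do as well, such as an unsubstituted 1,3-thiazol-4-yl or a phenyl ring. A group without an aromatic ring, such as a cyclohexyl ring or a longer chain like butyl, would show whether aromaticity or mere size goes with the lower number.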